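A few compounds are considered here, and "the series" means these few. Any claim that something is new, unique, unknown or untested is made for them only; others in the source may bear on it.

Compound 1, `COC1=C(C)C(=O)/C(=C(O)/C=C/c2ccc(F)cc2)C(=O)C1(C)C`, and compound 2, `C=Cc1ccccc1/C=C/C(O)=C1/C(=O)C(C)=C(OC)C(C)(C)C1=O`, share one core and differ only in the ring carried at the end of the chain. In a functional assay on PC-3 cells (Homo sapiens) for cytotoxicity (a lower number here means that less compound is needed, a higher number that more compound is needed for the effect), compound 1 gives 7.2 ug/mL, the highest of the two numbers seen so far, while compound 2 gives 4.6 ug/mL; the step of a 1.6-fold lower number from compound 1 to compound 2 (0.19 log units; within the scatter) stays within the scatter.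

Compound 3, `COC1=C(C)C(=O)/C(=C(O)/C=C/c2nccs2)C(=O)C1(C)C`, has not yet been tested. It differs from compound 1 in one place: 1,3-thiazol-2-yl in place of 4-fluorophenyl on a double-bonded chain carbon bound to a double-bonded chain carbon. For the measured compounds named here, only one measured step bears on this kind of change, and it is a 1.6-fold lower number from compound 1 to compound 2 (0.19 log units; within the scatter), a ring swap at the same chain carbon that did not move the number beyond the scatter. On that basis no step beyond the scatter is expected here either, in either direction. Compound 3 is therefore estimated at 7 ug/mL, with a range from 3 ug/mL to 17 ug/mL. The expected step is then a 1.0-fold lower number from compound 1 to compound 3 (0.01 log units; within the scatter).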

Compound 3, concentration for half-maximal effect: 10.8 ug/mL
Compound 3: the middle estimate sits 1.5-fold (0.19 log units) below what was measured; measured number inside the range.
By their numbers in this assay, from the lowest: compounds 2, 1 and 3 (each within the scatter of the next, the first and the last beyond it).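

Replacing 4-fluorophenyl with 1,3-thiazol-2-yl gives a 1.5-fold higher number from compound 1 to compound 3 (0.18 log units; within the scatter) in this assay, so this chain carbon can carry a five-membered aromatic ring with 2 hetero atoms as well as a six-membered aromatic ring of carbon only, without a clear change in the number. Replacing 2-vinylphenyl with 1,3-thiazol-2-yl gives a 2.3-fold higher number from compound 2 to compound 3 (0.37 log units; beyond the scatter), the only step among these compounds beyond the scatter, so the choice of ring here can move the number, though only modestly. Nothing available explains this difference.

On these data alone, all three compounds carry an aromatic ring at this place, so the effect of an amine, a carboxylic acid or a longer alkyl chain there remains open. The shared core is also the same throughout, leaving open how changes elsewhere would read in this assay.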